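The compounds below may be only part of what the source reports. "The series", "measured", "known", "first", "only" and "open" are said of these compounds alone.

Measured compounds in an assay on HEK293 cells for displacement of a labelled ligand from 5-hydroxytryptamine receptor 7 (Homo sapiens); a higher number here means a weaker inhibitor, a lower number a stronger inhibitor:

- compound 1 `COc1ccccc1N1CCN(Cc2ccc(CN3C(=O)c4ccccc4S3(=O)=O)cc2)CC1`: 97 nM
- compound 2 `O=C1c2ccccc2S(=O)(=O)N1CCCCCCN1CCN(c2ncccn2)CC1`: 2520 nM
- compound 3 `O=C1c2ccccc2S(=O)(=O)N1CCCCCN1CCN(c2ccccn2)CC1`: 179 nM

Compound 2 stands at the highest number of the three. Compound 3 is the nearest and lies well below it, beyond the scatter; compound 1 is the furthest and lies lower still, also beyond the scatter. Both compounds with an all-carbon or single-nitrogen aromatic ring on the ring amine nitrogen thus give clearly lower numbers in this assay than compound 2, though the chain and the substitution pattern differ across the three, so no clean single-change comparison exists among the measured compounds.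

Compound 4 `O=C1c2ccccc2S(=O)(=O)N1CCCCCCN1CCN(c2ccc(Cl)cc2)CC1` is not yet measured. It differs from compound 2 in one place: 4-chlorophenyl in place of pyrimidin-2-yl on an amine nitrogen in a ring.

Within the data shown here, no step between measured compounds matches this change. The expectation for this assay rests on compound 1 with 97 nM and compound 3 with 179 nM both standing well below compound 2; a downward step beyond the scatter from compound 2 to compound 4 is therefore expected, as an 11-fold lower number from compound 2 to compound 4 (1.06 log units; beyond the scatter). For compound 4 the estimated value in this assay is 220 nM, with a range from 60 nM to 800 nM.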

Compound 4, inhibition constant: 487 nM
Compound 4: middle estimate off by 2.2-fold (0.35 log units), on the low side; the range from low to high includes it.
By their numbers in this assay, from the lowest: compounds 1 and 3 (each within the scatter of the next); then compound 4; then compound 2.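

In this assay, the series now has its first comparison that differs in one place, a 5.2-fold lower number from compound 2 to compound 4 (0.71 log units; beyond the scatter), so 4-chlorophenyl in place of pyrimidin-2-yl on this amine nitrogen in a ring lowers the number beyond the scatter while the rest of compound 2 stays unchanged. The earlier compounds shown here could not separate the group on this nitrogen from their other structural differences, whereas this pair shows that the group alone moves the value, although the step is modest. The change removes the hydrogen-bond acceptors and ring nitrogens of pyrimidin-2-yl and brings in a ring of carbon only with a chlorine, but no measurement here explains why the number falls.

As far as these compounds go, it remains open whether the step comes from the chlorine, from the loss of the ring nitrogens or from both, since the two changes arrive together; an unsubstituted phenyl on the same nitrogen would separate them. From the compounds shown here alone, it is also open whether the step carries over to a shorter chain or to another group at the same place, such as 4-fluorophenyl.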